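Ring swap on the amide-type nitrogen: compound 4

The source may report more compounds than this note shows. Statements on the series, on what has been measured and on what is new or still open speak of the compounds shown alone.

Three compounds of the shared core carry measured numbers. Compound 1 `C[C@H]1C[C@H](c2nc(-c3ccc4ccccc4n3)no2)CCN1C(=O)Nc1ccccc1Cl` gives 900 nM in a functional assay on Shh Light II cells (Mus musculus) for inhibition, read by a luciferase reporter; on this read-out lower numbers stand for stronger inhibition and higher numbers for weaker inhibition; compound 2 `O=C(NC1CC[S+]([O-])CC1)N1CCC(c2nc(-c3ccc4ccccc4n3)no2)CC1` gives 850 nM, and compound 3 `Cc1ccccc1NC(=O)N1CCC(c2nc(-c3ccc4ccccc4n3)no2)CC1` gives 440 nM. Compound 2 stands second highest of the three numbers, nearest compound 1 and furthest from compound 3, with every gap within the scatter. Compound 4 `O=C(NC1CCNCC1)N1CCC(c2nc(-c3ccc4ccccc4n3)no2)CC1` differs from compound 2 by a group of 6 heavy atoms (5 carbon, 1 nitrogen; one six-membered non-aromatic ring with 1 hetero atom) in place of a group of 7 heavy atoms (5 carbon, 1 oxygen, 1 sulfur; one six-membered non-aromatic ring with 1 hetero atom), on an amide-type nitrogen. For the measured compounds named here, the one measured step at the same site is a 1.9-fold lower number from compound 2 to compound 3 (0.29 log units; within the scatter), which did not move the number beyond the scatter. On that basis no step beyond the scatter is expected for compound 4 in this assay. The expected step is no change at the digits printed from compound 2 to compound 4 (within the scatter). Compound 4 is accordingly estimated at 850 nM, with a range from 350 nM to 2000 nM.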

Compound 4, half-maximal inhibitory concentration: 2500 nM
Beside the measured number, compound 4's estimate is 2.9-fold (0.47 log units) below it; the measured number lies above the stated range.
By their numbers in this assay, from the lowest: compounds 3, 2 and 1 (each within the scatter of the next, the first and the last beyond it); then compound 4.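

In this assay the group on the amide-type nitrogen can move the number beyond the scatter: piperidin-4-yl gives a 2.9-fold higher number from compound 2 to compound 4 (0.47 log units; beyond the scatter) and also a 5.7-fold higher number from compound 3 to compound 4 (0.75 log units; beyond the scatter). Compound 2 and compound 4 both carry a six-membered non-aromatic ring with one hetero atom, so the change in hetero atom and its substitution is enough to shift the number. Nothing at hand explains this shift.

Going by these compounds, whether the hydrogen-bond donor of piperidin-4-yl or the ring nitrogen itself goes with the higher number stays open. A tetrahydropyran-4-yl group, or an acetyl group on the ring nitrogen, would bear on that question.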